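This account rests on a few compounds, and the source may have more. Where it says the series, first, only, none or still open, it means among the compounds named here.

Measured in a functional assay on J774.A1 cells (Mus musculus) for inhibition, read by Griess assay, with stated times of 1 h and 24 h; on this read-out lower numbers stand for stronger inhibition and higher numbers for weaker inhibition:
- compound 1 `CC(C)c1ccc(COc2ccccc2C2CC(=O)c3ccccc3O2)cc1`: 28600 nM
- compound 2 `CCCCCOc1ccccc1C1CC(=O)c2ccccc2O1`: 39300 nM
- compound 3 `O=C1CC(c2ccccc2OCc2ccccc2)Oc2ccccc21`: 23200 nM

Not yet measured: compound 4 `COc1ccccc1C1CC(=O)c2ccccc2O1`.

Compound 1 lies within the scatter of both other compounds, and compounds 2 and 3 lie within the scatter of each other, so the three numbers give no order.

The step under consideration puts hydrogen in place of 4-isopropylphenyl on a saturated chain carbon bound to an oxygen on an aromatic ring.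

Two measured steps change the same place. One is a 1.4-fold higher number from compound 1 to compound 2 (0.14 log units; within the scatter), with butyl in place of 4-isopropylphenyl. The other is a 1.7-fold lower number from compound 2 to compound 3 (0.23 log units; within the scatter), with phenyl in place of butyl. A third, a 1.2-fold lower number from compound 1 to compound 3 (0.09 log units; within the scatter), removes isopropyl from the aromatic ring of that same group. All three are small. For the measured compounds named here, none of the measured compounds carries hydrogen at this place, however, so the expectation is an extrapolation and its range is kept wide.

No step beyond the scatter is expected in this assay, and no direction can be assigned with confidence. The estimated step is a 1.2-fold higher number from compound 1 to compound 4 (0.06 log units; within the scatter). For compound 4 the expected value is 33000 nM, with an estimated range of 14000 nM to 80000 nM.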

Compound 4, half-maximal inhibitory concentration: 44500 nM
The estimate for compound 4 lay 1.3-fold (0.13 log units) below the measured number, within the range that was stated.
By their numbers in this assay, from the lowest: compounds 3, 1, 2 and 4 (each within the scatter of the next).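

In this assay, hydrogen at this place, on a saturated chain carbon bound to an oxygen on an aromatic ring, was compared directly with each of the three larger groups: 4-isopropylphenyl (a 1.6-fold higher number from compound 1 to compound 4 (0.19 log units; within the scatter)), phenyl (a 1.9-fold higher number from compound 3 to compound 4 (0.28 log units; within the scatter)) and butyl (a 1.1-fold higher number from compound 2 to compound 4 (0.05 log units; within the scatter)). The earlier compounds shown here only exchanged one large group for another, whereas these steps show that removing the whole group, including the 9 heavy atoms of 4-isopropylphenyl, gives no step beyond the scatter, so all four compounds remain without an order at this place. No measurement on hand bears on why the read-out stays flat across this change.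

On these data alone, how an amine or a carboxylic acid at this place would read remains open, as does a chain longer than butyl. As far as these compounds go, whether any change elsewhere on the shared core gives a step beyond the scatter also remains open.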